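The source may hold more compounds than are shown below. What is called first, only, known or untested is meant among the compounds shown, and "the series" means these compounds.

Compound 1 `COc1ccc(NCCNC(=O)[C@@H](NC(=O)c2cccc(C)c2)C2CCCCC2)cc1`, compound 2 `COc1ccc(NCCNC(=O)[C@H](CC2CCCCC2)NC(=O)c2ccc(-c3ccc(Cl)cc3)o2)cc1` and compound 3 `COc1ccc(NCCNC(=O)[C@H](CC2CCCCC2)NC(=O)c2ccc(Nc3nc(C)cc(C)n3)cc2)cc1` were all tested in an assay on isolated protein for inhibition of cathepsin S (Homo sapiens), at 37 degrees C, at pH 5.5; a lower number here means a stronger inhibitor, a higher number a weaker inhibitor. Compound 1 gave 23 nM, compound 2 gave 7.1 nM, and compound 3 gave 2 nM, the lowest number of the three, with its gaps to both compound 2 and compound 1 lying beyond the usual scatter. Compound 4 `COc1ccc(NCCNC(=O)[C@H](CC2CCCCC2)NC(=O)c2ccc(-c3cccc(Cl)c3)cc2)cc1` has not yet been measured; it differs from compound 3 by 3-chlorophenyl in place of (4,6-dimethylpyrimidin-2-yl)amino on an aromatic carbon. Compound 2 already carries a chlorophenyl group and gave 7.1 nM, so the number for compound 4 is expected to move upward a little from that of compound 3, near the edge of the scatter: the expected step is a 3.0-fold higher number from compound 3 to compound 4 (0.48 log units; beyond the scatter). In this assay compound 4 is therefore estimated at 6 nM, within a range from 2 nM to 20 nM.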

Compound 4, inhibition constant: 7.4 nM
Compound 4: the middle estimate sits 1.2-fold (0.09 log units) below what was measured; measured number inside the range.
By their numbers in this assay, from the lowest: compound 3; then compounds 2 and 4 (each within the scatter of the next); then compound 1.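

On an aromatic carbon para to a large group, 3-chlorophenyl in place of (4,6-dimethylpyrimidin-2-yl)amino gives a 3.7-fold higher number from compound 3 to compound 4 (0.57 log units; beyond the scatter) in this assay. This position therefore accepts a ring of carbon only, with no hydrogen-bond donors or acceptors, but the number rises beyond the scatter. No measurement shown accounts for this step. On these data alone, it remains open whether the lower number of compound 3 depends on the amine hydrogen, the ring nitrogens or the two methyl groups. As far as these compounds go, how plain phenyl or 4-chlorophenyl would compare at this position also remains open.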